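The source may hold more compounds than are shown below. What is called first, only, known or untested is meant among the compounds shown, and "the series" means these compounds.

Working notes on the enone series. Compound 1 `C#CCOc1ccc(/C=C/C(=O)c2cccc(OC)c2)cc1OC` gives 1100 nM in a functional assay on ADR5000 cells for cytotoxicity against ADR5000 cell line (Homo sapiens), with a stated time of 72 h; on this read-out lower numbers stand for stronger inhibition and higher numbers for weaker inhibition. Compound 2 `C#CCOc1ccc(/C=C/C(=O)c2ccc(-n3ccnc3)cc2)cc1OC` gives 1000 nM and compound 3 `C#CCOc1ccc(/C=C/C(=O)c2ccc(OC)c(OC)c2)cc1OC` gives 1440 nM in this assay. Compound 1 stands within the scatter of both neighbours: the step of a 1.3-fold higher number from compound 1 to compound 3 (0.12 log units; within the scatter) is small, and the values of compound 1 and compound 2 also lie within the scatter of each other, so no order among the three can be read.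

Compound 4 `C#CCOc1ccc(/C=C/C(=O)c2ccccc2C)cc1OC` carries the change (2-methylphenyl in place of 3-methoxyphenyl on a carbonyl carbon). For the measured compounds named here, the only measured step on this ring is a 1.3-fold higher number from compound 1 to compound 3 (0.12 log units; within the scatter), which stays inside the scatter; compound 2, which carries a different substituent on the same ring, also stays inside the scatter relative to compound 1. Three substitutions of this ring thus leave this assay essentially unchanged, so no step beyond the scatter is expected from the step of a 1.1-fold higher number from compound 1 to compound 4 (0.04 log units; within the scatter).

For compound 4 the expected value in this assay is 1200 nM, with a range from 600 nM to 2400 nM.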

Compound 4, half-maximal inhibitory concentration: 920 nM
Compound 4: middle estimate off by 1.3-fold (0.12 log units), on the high side, within the range that was stated.
By their numbers in this assay, from the lowest: compounds 4, 2, 1 and 3 (each within the scatter of the next).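

In this assay, the change gives a 1.2-fold lower number from compound 1 to compound 4 (0.08 log units; within the scatter), so this step, too, shows no measurable effect at this position. It extends the earlier picture in one respect: the entering 2-methylphenyl is made of carbon only and counts no hydrogen-bond acceptor, while the leaving 3-methoxyphenyl counts one, and this loss of the oxygen does not move the number beyond the scatter. Nothing available explains this flat outcome.

The compounds shown leave open whether an amine or a carboxylic acid on this ring would move the number beyond the scatter. They also leave open whether a longer chain on the same ring, or any change elsewhere on the shared core, would do so.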